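Benzoylsulfamoyl in Place of the Tetrazole: Expected Potency

This account rests on a few compounds, and the source may have more. Where it says the series, first, only, none or still open, it means among the compounds named here.

Measured compounds:
compound 1, `CC(O)Cn1nnc(-c2ccccc2-c2ccc(CN3C(=O)[C@H](NC(=O)CC(C)(C)N)CCc4ccccc43)cc2)n1`, 0.05 uM
compound 2, `CC(C)(N)CC(=O)N[C@@H]1CCc2ccccc2N(Cc2ccc(-c3ccccc3S(N)(=O)=O)cc2)C1=O`, 3 uM

Compound 1 carries a 2-(2-hydroxypropyl)-2H-tetrazol-5-yl group on an aromatic carbon of its core. Among the measured compounds shown here, in a functional assay (Pituitary gland cell) with Rattus norvegicus as the target (a lower number here means that less compound is needed, a higher number that more compound is needed for the effect), compound 1 gives 0.05 uM, the lowest of the two numbers known here. Compound 2 replaces that tetrazole with sulfamoyl, and in this assay compound 2 gives 3 uM; the step is a 60-fold higher number from compound 1 to compound 2 (1.78 log units; beyond the scatter), a large loss.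

Compound 3, `CC(C)(N)CC(=O)N[C@@H]1CCc2ccccc2N(Cc2ccc(-c3ccccc3S(=O)(=O)NC(=O)c3ccccc3)cc2)C1=O`, has not yet been measured. It differs from compound 1 as follows: benzoylsulfamoyl in place of 2-(2-hydroxypropyl)-2H-tetrazol-5-yl on an aromatic carbon. For the measured compounds named here, the only measured step that bears on this change is the one from compound 1 to compound 2, in which the tetrazole also left the same aromatic carbon; that step was large and went toward a higher number. Compound 3 keeps a sulfamoyl-type group at the same place but carries the benzoyl in addition, and the data give no direct reading for that extra group. The expectation for compound 3 is therefore a higher number than compound 1, most likely less than the step seen for compound 2, i.e. an expected step of a 10-fold higher number from compound 1 to compound 3 (1.00 log units; beyond the scatter). The estimate for compound 3 in this assay is 0.5 uM, with a range from 0.1 uM to 3 uM.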

Compound 3, concentration for half-maximal effect: 3 uM
For compound 3 the middle estimate is 6.0-fold (0.78 log units) below the measured one, within the range that was stated.
By their numbers in this assay, from the lowest: compound 1; then compounds 2 and 3 (each within the scatter of the next).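

In this assay, the benzoylsulfamoyl group does not make up for the departure of the 2-(2-hydroxypropyl)-2H-tetrazol-5-yl group: the result is a 60-fold higher number from compound 1 to compound 3 (1.78 log units; beyond the scatter), so a large loss at this aromatic carbon, ortho to a large group, is now seen with a second sulfonyl-bearing replacement and not with the plain sulfamoyl alone. Benzoyl in place of hydrogen on the sulfonamide nitrogen gives no change at the digits printed from compound 2 to compound 3 (within the scatter), which shows that adding this group, with its six-membered aromatic ring of carbon only, leaves the reading where it was. Nothing given here accounts for either result.

Going by these compounds, what remains open is whether the low number of compound 1 depends on the tetrazole ring or on its 2-hydroxypropyl chain, a question that a 2H-tetrazol-5-yl group carrying a methyl in place of that chain would help to separate. Also open, on these data alone, is how a carboxylic acid on the same aromatic carbon, or an acetyl in place of the benzoyl on the sulfonamide nitrogen, would read in this assay.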